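This account rests on a few compounds, and the source may have more. Where it says the series, first, only, none or still open, it means among the compounds named here.

Of the compounds shown here, two have numbers so far in a functional assay for inhibition, with Homo sapiens as the target; a lower number here means that less compound is needed, a higher number that more compound is needed for the effect. Compound 1 (`CCCC(=O)Nc1ccc(C2=NNC(=O)CC2)cc1`) gives 1.44 ug/mL, the lower of the two values. Compound 2 (`CC1CC(c2ccc(N)cc2)=NNC1=O`) gives 43.8 ug/mL, a higher number beyond the usual scatter. These two compounds differ in more than one place, so their gap cannot be assigned to any single change.

Compound 3 (`O=C1CCC(c2ccc(NC(=O)CCCCl)cc2)=NN1`) has not yet been measured. It differs from compound 1 in one place: chloro in place of hydrogen on a saturated chain carbon, three bonds along the chain from a carbonyl carbon. In words, this is chloro in place of hydrogen on a saturated chain carbon, three bonds along the chain from a carbonyl carbon. The same difference can be read as propyl to 3-chloropropyl.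

Among the measured compounds shown here, no measured pair shows a change of this kind, so the data offer no direct guide to its size or direction. In this assay, no step beyond the scatter is expected, and the expectation stays anchored on compound 1 at 1.44 ug/mL. The estimated step is a 1.0-fold higher number from compound 1 to compound 3 (0.02 log units; within the scatter). The expected value for compound 3 is 1.5 ug/mL, with an estimated range of 0.5 ug/mL to 5 ug/mL.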

Compound 3, half-maximal effective concentration: > 46.4 ug/mL
Compound 3 ended at the assay's limit; the forecaster's own chance of this, stated with the estimate: 3%; middle value at least 30-fold (1.49 log units) away from the limit.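

Among the compounds shown here, the change from propyl to 3-chloropropyl, a single chlorine atom on a saturated chain carbon three bonds along the chain from a carbonyl carbon, is the first one-place comparison, and in this assay it amounts to an at least 32-fold higher number from compound 1 to compound 3 (1.50 log units; beyond the scatter). The end of this chain is therefore not a free place for substitution in this read-out, something the gap between the two earlier compounds, which differ in more than one place, could not show. The value of compound 3, > 46.4 ug/mL, is a limit of the assay and not a number, so the step has a lower end only: the limit of > 46.4 ug/mL in this assay, at which 1 of the 3 values shown sits.

As far as these compounds go, whether a hydroxyl group, an amine or a longer chain at this place would behave like the hydrogen of compound 1 or like the chloro group of compound 3 remains open. Equally open, from the compounds shown here alone, is whether the step belongs to chloro as such or to any replacement of hydrogen on this carbon.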